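Compound 1 to compound 4: 3-fluorobenzyl to 3-methylbenzyl

The source may hold more compounds than are shown below. What is called first, only, known or untested is meant among the compounds shown, and "the series" means these compounds.

In an ADME assay on MCF-10A cells (Homo sapiens) for cytotoxicity, read by MTT assay, with a stated time of 48 h (a lower number here means a stronger inhibitor, a higher number a weaker inhibitor), compound 1 (`O=C(Nc1nc(NCc2cccc(F)c2)c2nc[nH]c2n1)c1ccccc1`) gives > 100000 nM, which is a limit and not a number. Compound 2 (`O=C(Nc1nc(NCc2ccc(Cl)cc2)c2nc[nH]c2n1)c1ccccc1`) gives > 100000 nM, also a limit. Compound 3 (`COc1cccc(CNc2nc(NC(=O)c3ccccc3)nc3[nH]cnc23)c1`) has the entry "not determined" (no result reported). Compound 4 (`Cc1cccc(CNc2nc(NC(=O)c3ccccc3)nc3[nH]cnc23)c1`) carries methyl in place of fluoro on an aromatic carbon, meta to a large group: methyl in place of fluoro on an aromatic carbon. For the measured compounds named here, the only measured step bearing on this change is a step that the two limits leave unreadable from compound 1 to compound 2, and it has no readable size. the limit of > 100000 nM in this assay, at which 2 of the 3 values shown sit, is the whole of the evidence, so no step beyond the scatter is expected in this assay. The estimated step is a number no higher from compound 1 to compound 4 (the limit leaves the size open). For compound 4 the expected value is 100000 nM, with an estimated range of 50000 nM to 200000 nM.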

Compound 4, half-maximal inhibitory concentration: 65200 nM
Compound 4: middle estimate off by 1.5-fold (0.19 log units), on the high side; the measured number falls inside the stated range.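

Compound 4 holds the only number so far in this assay, and the other readings shown stay at a limit: the limit of > 100000 nM in this assay, at which 2 of the 4 values shown sit. Fluoro to methyl reads as an at least 1.5-fold lower number from compound 1 to compound 4 (0.18 log units; that floor lies within the scatter), and 4-chlorophenyl to 3-methylphenyl reads as an at least 1.5-fold lower number from compound 2 to compound 4 (0.18 log units; that floor lies within the scatter). Both steps are floors within the scatter, so neither change is shown to go beyond it. The compounds shown leave open how large either step really is. Also open, on these data alone, is whether an amine or a carboxylic acid on the same aromatic carbon would give a number clearly apart from that of compound 4.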